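The source may report more compounds than this note shows. Statements on the series, on what has been measured and on what is new or still open speak of the compounds shown alone.

Measured compounds in an ADME assay on Huh-5-2 cells (Homo sapiens) for cytotoxicity, read by WST assay, with a stated time of 3 days; on this read-out lower numbers stand for higher toxicity in this test and higher numbers for lower toxicity in this test:
- compound 1, `O=c1c(OCc2ccccc2Br)c(-c2ccccc2)oc2cc(O)cc(O)c12`, gives 12000 nM in this assay
- compound 2, `O=c1c(OCc2cccc(Br)c2)c(-c2ccccc2)oc2cc(O)cc(O)c12`, gives 15000 nM in this assay
- compound 3, `O=c1c(OCc2cccc([N+](=O)[O-])c2)c(-c2ccccc2)oc2cc(O)cc(O)c12`, gives 31000 nM in this assay

Compound 3 stands highest of the three numbers in this assay: a 2.1-fold higher number from compound 2 to compound 3 (0.32 log units; beyond the scatter), and a 2.6-fold higher number from compound 1 to compound 3 (0.41 log units; beyond the scatter), both beyond the scatter, whereas a 1.3-fold higher number from compound 1 to compound 2 (0.10 log units; within the scatter). Compound 4, `COc1cccc(COc2c(-c3ccccc3)oc3cc(O)cc(O)c3c2=O)c1`, differs from compound 3 by methoxy in place of nitro on an aromatic carbon. The step that bears most directly on this change is the exchange of the group on that aromatic carbon, a 2.1-fold higher number from compound 2 to compound 3 (0.32 log units; beyond the scatter), which was modest. Among the measured compounds shown here, no measured compound carries a methoxy group, so the data give no direction for this particular exchange. The measured steps in this assay are all small to modest, so a step of similar size or none beyond the scatter is expected, with no firm sign for its direction. Compound 4 is therefore expected to give 22000 nM in this assay, within a range of 9000 nM to 50000 nM, which means an estimated step of a 1.4-fold lower number from compound 3 to compound 4 (0.15 log units; within the scatter).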

Compound 4, half-maximal cytotoxic concentration: 28000 nM
Beside the measured number, compound 4's estimate is 1.3-fold (0.10 log units) below it; low and high end bracket the measured number.
By their numbers in this assay, from the lowest: compounds 1, 2, 4 and 3 (each within the scatter of the next, the first and the last beyond it).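

In this assay, the exchange of nitro for methoxy on this aromatic carbon gives a 1.1-fold lower number from compound 3 to compound 4 (0.04 log units; within the scatter), so this second group at the same place cannot be told apart from nitro. Methoxy in place of bromo gives a 1.9-fold higher number from compound 2 to compound 4 (0.27 log units; within the scatter), which means that compound 4 cannot be separated from either compound 2 or compound 3, even though those two compounds are printed as lying beyond the scatter of each other. Only the comparison with the 2-bromophenyl compound, a 2.3-fold higher number from compound 1 to compound 4 (0.37 log units; beyond the scatter), goes beyond the scatter, and it remains modest. Nothing given here accounts for these numbers.

The compounds shown leave open whether an amine or a carboxylic acid on this aromatic carbon would stay in the same range. They also leave open whether a longer chain in place of methoxy would do so.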